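Imidazole for triazole on the aryl of compound 3

The source may report more compounds than this note shows. Statements on the series, on what has been measured and on what is new or still open speak of the compounds shown alone.

Measured compounds:
compound 1, `CN(C)c1ccc(C2CC(c3ccc(-n4ccnc4)cc3)=NN2)cc1`, 0.1%
compound 2, `CC(=O)N1N=C(c2ccc(N3CCN(C)CC3)cc2)CC1c1ccc(N(C)C)cc1`, -1.9%
compound 3, `CC(=O)N1N=C(c2ccc(-n3cncn3)cc2)CC1c1ccc(N(C)C)cc1`, -0.3%

In a functional assay on NCI-H1975 cells (Homo sapiens) for inhibition, read by sulforhodamine B assay, tested at 10 uM (on this read-out higher numbers stand for more inhibition at the one concentration tested (going by the name of the read-out) and lower numbers for less inhibition), compound 3 gives -0.3%, the second highest of the three numbers; its neighbours are compound 1 with 0.1% and compound 2 with -1.9%, both within the scatter of it, so no order among the three can be read. Among the measured compounds shown here, the only measured step, a number 1.6 percentage points higher from compound 2 to compound 3 (within the scatter), swaps one group on an aromatic carbon of the same ring and leaves the read-out within the scatter. Compound 4, `CC(=O)N1N=C(c2ccc(-n3ccnc3)cc2)CC1c1ccc(N(C)C)cc1`, differs from compound 3 by 1H-imidazol-1-yl in place of 1H-1,2,4-triazol-1-yl on an aromatic carbon. Compound 1 carries the same imidazole on the same aryl without the acetyl of compound 3, and its value and that of compound 3 lie within the scatter of each other. For the measured compounds named here, since the one measured exchange at this position moved nothing beyond the scatter, the step of a number 0.3 percentage points higher from compound 3 to compound 4 (within the scatter) is expected to be none beyond the scatter. Compound 4 is therefore estimated at 0%, between -9% and 9%.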

Compound 4, a percentage reported as inhibition, at one concentration (the size of the read-out at that concentration, not a potency): -2.1%
Compound 4: the middle estimate sits 2.1 percentage points above what was measured, within the range that was stated.
By their numbers in this assay, from the lowest: compounds 4, 2, 3 and 1 (each within the scatter of the next).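

In this assay, 1H-imidazol-1-yl in place of 1H-1,2,4-triazol-1-yl on the aromatic carbon gives a number 1.8 percentage points lower from compound 3 to compound 4 (within the scatter) and 1H-imidazol-1-yl in place of 4-methylpiperazin-1-yl gives a number 0.2 percentage points lower from compound 2 to compound 4 (within the scatter), so three different groups at this position now read alike. The acetyl on the amine nitrogen in the ring also makes no difference that can be read here, with acetyl in place of hydrogen giving a number 2.2 percentage points lower from compound 1 to compound 4 (within the scatter), so neither place has moved the number beyond the scatter in these compounds. Nothing available offers an explanation for these numbers.

From the compounds shown here alone, it remains open whether any group on this aryl separates from these values, such as a carboxylic acid or a primary amine. The same holds on the ring nitrogen for a longer acyl chain in place of acetyl.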